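Swapping a hydroxyl-bearing ring for a chloro-bearing one

The source may hold more compounds than are shown below. What is called first, only, known or untested is meant among the compounds shown, and "the series" means these compounds.

Compound 3 `Oc1cccc(-c2ccc(NCc3ccccc3O)cc2)c1` was tested in a functional assay on Jurkat cells (Homo sapiens) for activation, with a stated time of 24 h (a lower number here means that less compound is needed, a higher number that more compound is needed for the effect), and came back as "not active" (no number reported), so no number stands against it. Compound 1 `Oc1ccccc1CNc1ccc(F)cc1` also gave "not active" (no number reported) in this assay. Compound 2 `Cc1cccc(-c2ccc(NCc3ccccc3O)cc2)c1` gave 9190 nM in this assay. Compound 4 `Oc1ccccc1CNc1ccc(-c2ccccc2Cl)cc1` differs from compound 3 by 2-chlorophenyl in place of 3-hydroxyphenyl on an aromatic carbon. For the measured compounds named here, with compound 3 lacking a number, no measured step to compare with is available; the step from compound 3 to compound 4 is expected to move toward a measurable, weak effect, in the direction of less compound being needed. The expectation rests on compound 2, which gives 9190 nM in this assay. Compound 4 is estimated at 9000 nM, within 3000 nM to 30000 nM.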

Compound 4, half-maximal effective concentration: "not active" (no number reported)
Compound 4 has no reported number here; no gap can be computed for the estimate.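

In this assay, for the compounds shown here, compound 3 and compound 4 both came back as not active, so no step between them can be read. Going by these compounds, whether 2-chlorophenyl and 3-hydroxyphenyl differ in effect stays open. No evidence on hand bears on this result.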